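Carboxypyridinyl for pyrimidinyl: solubility outlook for compound 4

A few compounds are considered here, and "the series" means these few. Any claim that something is new, unique, unknown or untested is made for them only; others in the source may bear on it.

Compound 1 `FC(F)(F)c1cccc(-c2nc3cnc(Nc4ncccn4)cc3[nH]2)c1` is the reference point of this step. In a physicochemical assay for solubility, using the shake flask method, in phosphate buffer, measured as kinetic solubility, with a stated time of 20 h, at pH 6.5 (a higher number here means a more soluble compound, a lower number a less soluble compound), compound 1 gives < 5000 nM, which is a limit of the assay and not a number. Compound 2 `Fc1ccc(-c2nc3cnc(Nc4ccccn4)cc3[nH]2)cc1F` and compound 3 `Fc1ccc(-c2nc3cnc(Nc4ccc(C(F)(F)F)cn4)cc3[nH]2)cc1F` make up the rest of the measured set. In this assay compound 2 gives < 5000 nM, a limit. In this assay compound 3 gives < 5000 nM, again a limit. Compound 1 thus stands at the same limit as the other two measured compounds, as the limit of < 5000 nM in this assay, at which 3 of the 3 values shown sit, records, and no ordering among the three can be read.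

Going by the values given here, the single measured step, a step that the two limits leave unreadable from compound 2 to compound 3, concerns a different part of the molecule and is in any case unreadable. Compound 4 `O=C(O)c1ccnc(Nc2cc3[nH]c(-c4cccc(C(F)(F)F)c4)nc3cn2)c1` differs from compound 1 by 4-carboxypyridin-2-yl in place of pyrimidin-2-yl on a nitrogen on an aromatic ring. Among the compounds with values here, no measured step covers such a change, so the data do not fix its size or direction; with every measured value at the limit, only an upward move could become visible. The expectation for compound 4 is 40000 nM, with a range from 5000 nM to 300000 nM. This estimate corresponds to an expected step of an at least 8.0-fold higher number from compound 1 to compound 4 (0.90 log units; beyond the scatter).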

Compound 4, solubility: < 5000 nM
Compound 4: no number, only a limit; the forecaster's own chance of this, stated with the estimate: 30%; at least 8.0-fold (0.90 log units) between middle value and limit.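

No new step can be read from compound 1 to compound 4 in this assay, as both values are limits and not numbers: the limit of < 5000 nM in this assay, at which 4 of the 4 values shown sit.

The compounds shown leave open how the four rank in this assay, and whether 4-carboxypyridin-2-yl in place of pyrimidin-2-yl changes the read-out at all.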